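Aryl swap on the fused core: compound 2 to compound 3

The source may hold more compounds than are shown below. What is called first, only, known or untested is meant among the compounds shown, and "the series" means these compounds.

In an assay on isolated protein for agonist activity at Free fatty acid receptor 1 (Homo sapiens) (on this read-out lower numbers stand for an effect already at smaller amounts and higher numbers for an effect only at larger amounts of compound), compound 2 `CC#CC(CC(=O)O)c1ccc(OCc2ccc3nc(-c4ccc(F)cc4F)cn3c2)cc1` gives 825 nM. Compound 1 `CC#CC(CC(=O)O)c1ccc(OCc2ccn3cc(-c4ccc(C)cc4)nc3c2)cc1` gives 618 nM in this assay; the two values lie within the usual scatter of each other, and the numbers shown do not separate them. Compound 3 `CC#CC(CC(=O)O)c1ccc(OCc2ccc3nc(-c4cccc(C)c4)cn3c2)cc1` differs from compound 2 by 3-methylphenyl in place of 2,4-difluorophenyl on an aromatic carbon. For the measured compounds named here, no measured pair isolates this change. The step of a 1.3-fold lower number from compound 2 to compound 3 (0.10 log units; within the scatter) is expected to be small, none beyond the scatter, with no direction implied. Compound 3 is estimated at 650 nM, with a range from 250 nM to 1700 nM.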

Compound 3, half-maximal effective concentration: 1050 nM
For compound 3 the middle estimate is 1.6-fold (0.21 log units) below the measured one, within the range that was stated.
By their numbers in this assay, from the lowest: compounds 1, 2 and 3 (each within the scatter of the next).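

In this assay, 3-methylphenyl in place of 2,4-difluorophenyl on this aromatic carbon of the five-membered ring gives a 1.3-fold higher number from compound 2 to compound 3 (0.10 log units; within the scatter). For the compounds shown here, this is the first pair that isolates a swap at this position, and these two substituted phenyl groups are not separated by the read-out. No measured evidence bears on this result.

On these data alone, whether any group on this carbon can give a step beyond the scatter remains open. A pyridine ring or a simple amine there would test this beyond substituted phenyl groups.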